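The compounds below may be only part of what the source reports. "The series", "measured", "known", "first", "only" and "open" are said of these compounds alone.

In a functional assay on RAW264.7 cells (Mus musculus) for inhibition, with a stated time of 30 min (a higher number here means a weaker inhibitor, a lower number a stronger inhibitor), compound 1 `C=C1C(=O)OC[C@H]1CCOC(=O)Nc1ccccc1` gives 390 nM.
In this assay compound 2 `C=C1C(=O)OC[C@H]1CCOC(=O)Nc1ccc(OC)cc1` gives 710 nM.
In this assay compound 3 `C=C1C(=O)OC[C@@H]1CCOC(=O)Nc1ccc(OC)cc1` gives 1090 nM.

Compound 2 stands second highest of the three numbers. The nearest number is one step away: a 1.5-fold higher number from compound 2 to compound 3 (0.19 log units; within the scatter), and here the two compounds differ only in configuration as drawn (the fact that compounds 2 and 3 differ only in the configuration as drawn). The furthest number is the other measured step: a 1.8-fold higher number from compound 1 to compound 2 (0.26 log units; within the scatter). Neither step leaves the scatter, so the three measured compounds cannot be ordered.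

Compound 4 `C=C1C(=O)OC[C@H]1CCOC(=O)Nc1ccc(Cl)cc1` differs from compound 2 by chloro in place of methoxy on an aromatic carbon. Going by the values given here, the only measured step that touches the same aromatic carbon is the substitution on that ring, and it stayed within the scatter. The configuration step does not bear on a substituent change. The para position has so far tolerated hydrogen and methoxy without a step beyond the scatter, so chloro is expected to behave alike in this assay, with no step beyond the scatter in either direction.

Compound 4 is therefore expected to give about 550 nM in this assay, with a range from 220 nM to 1400 nM. The expected step is a 1.3-fold lower number from compound 2 to compound 4 (0.11 log units; within the scatter).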

Compound 4, half-maximal inhibitory concentration: 390 nM
Estimate against measurement, compound 4: 1.4-fold (0.15 log units) above, and the stated range covers the measured number.
By their numbers in this assay, from the lowest: compounds 1, 4, 2 and 3 (each within the scatter of the next, the first and the last beyond it).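

In this assay chloro in place of methoxy on the aromatic carbon para to a large group gives a 1.8-fold lower number from compound 2 to compound 4 (0.26 log units; within the scatter) and chloro in place of hydrogen gives no change at the digits printed from compound 1 to compound 4 (within the scatter) on the same carbon. Hydrogen, methoxy and chloro at this position therefore all lie within the scatter of one another, and this includes the first exchange of a group with a hydrogen-bond acceptor for one without. No measurement given here bears on why these groups read alike.

Still open, going by these compounds, is whether any group at this position moves the number beyond the scatter, for example an amine, a carboxylic acid or a longer alkoxy chain. Also open is how the drawn configuration at the saturated ring carbon reads with chloro, as the pair of configurations shown carries methoxy alone.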